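A few compounds are considered here, and "the series" means these few. Any claim that something is new, unique, unknown or untested is made for them only; others in the source may bear on it.

Measured in an ADME assay on a cell-free system (plasma, Rattus norvegicus) for protein binding:
- Compound 1 `CNc1nccc(N2CC[C@H](NC(=O)Nc3ccc(CN(C)C)c(C(F)(F)F)c3)C2)n1`: 91%
- Compound 2 `CNc1nccc(N2CC[C@H](NC(=O)Nc3cc(OC)cc(OC)c3)C2)n1`: 96.7%

Of these two, compound 2 has the lower unbound fraction, at 96.7%, and its gap to compound 1 lies beyond the scatter. Compound 3 `CNc1nccc(N2CC[C@H](NC(=O)Nc3cccc(OC)c3)C2)n1` differs from compound 2 in one place: hydrogen in place of methoxy on an aromatic carbon, with hydrogen in place of methoxy on an aromatic carbon. Going by the values given here, no pair of measured compounds differs in only one place, so the expectation has no measured step to lean on and rests on this change and the two values alone. A modest move toward a higher unbound fraction is expected, of a size close to the scatter. The expected step is a 1.7-fold higher unbound fraction from compound 2 to compound 3 (0.22 log units; within the scatter). Compound 3 is estimated at 94.5%, with an expected range of 89% to 97.5%.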

Compound 3, plasma protein binding in the Rattus norvegicus assay: 93.9%
For compound 3 the middle estimate is 1.1-fold (0.04 log units) (unbound fraction) below the measured one; the range from low to high includes it.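

Going by these compounds alone, this is the first measured one-place step: in the Rattus norvegicus assay, compound 2 gives 96.7% and compound 3 gives 93.9%, and hydrogen in place of methoxy on an aromatic carbon gives a 1.8-fold higher unbound fraction from compound 2 to compound 3 (0.27 log units; within the scatter), so at this position the change stays within the scatter of the assay. In a physicochemical assay for solubility, measured as kinetic solubility (a lower number here means a less soluble compound, a higher number a more soluble compound), compound 2 gives 79400 nM and compound 3 gives 116000 nM, and the same change gives a 1.5-fold higher number from compound 2 to compound 3 (0.16 log units; within the scatter), which is also within the scatter, so neither read-out separates the two compounds on this single step. No measurement available here gives a reason for either step.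

The compounds shown leave open how a different group at this place, such as an amine, a carboxylic acid or a longer alkoxy chain, would read in either assay. They also leave open whether hydrogen in place of the remaining methoxy of compound 3 would give a step of similar size.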